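Adding a hydroxy to the phenyl of compound 3

The source may report more compounds than this note shows. Statements on the series, on what has been measured and on what is new or still open speak of the compounds shown alone.

Measured so far in a functional assay on cells (LY3.7.2C TK-/- cell line, Mus musculus); a lower number here means a stronger inhibitor, a higher number a weaker inhibitor:
Compound 1 `Cc1ccc2nc(N)nc(O)c2c1Sc1ccc(C(=O)N[C@H](C(=O)O)c2ccccc2)cc1` gives 800 nM
Compound 2 `Cc1ccc2nc(N)nc(O)c2c1Sc1ccc(C(=O)N[C@H](C(=O)O)c2cccc(O)c2)cc1` gives 600 nM
Compound 3 `COC(=O)[C@@H](NC(=O)c1ccc(Sc2c(C)ccc3nc(N)nc(O)c23)cc1)c1ccccc1` gives 500 nM

Compound 3 lies within the usual scatter of both other compounds, so these three values cannot be ranked. Compound 4 `COC(=O)[C@@H](NC(=O)c1ccc(Sc2c(C)ccc3nc(N)nc(O)c23)cc1)c1cccc(O)c1` carries 3-hydroxyphenyl where compound 3 carries phenyl. The difference is this: hydroxy in place of hydrogen on an aromatic carbon and the rest stays the same. The same swap has been measured once, as a 1.3-fold lower number from compound 1 to compound 2 (0.12 log units; within the scatter), and the methyl ester step, a 1.6-fold lower number from compound 1 to compound 3 (0.20 log units; within the scatter), was just as small. No shift beyond the scatter is therefore expected in this assay here. The estimated 1.3-fold lower number from compound 3 to compound 4 (0.10 log units; within the scatter) is expected to stay that small. Compound 4 is expected near 400 nM on this measure, with an estimated range from 200 nM to 800 nM as the likely span.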

Compound 4, half-maximal inhibitory concentration: 300 nM
Compound 4: the middle estimate sits 1.3-fold (0.12 log units) above what was measured; measured number inside the range.
By their numbers in this assay, from the lowest: compounds 4, 3, 2 and 1 (each within the scatter of the next, the first and the last beyond it).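

Placing hydroxy on the phenyl of the methyl ester gives a 1.7-fold lower number from compound 3 to compound 4 (0.22 log units; within the scatter) in this assay, a second reading of this change that agrees with the first: the same change on two cores in this assay, a 1.3-fold lower number (0.12 log units; within the scatter) from compound 1 to compound 2 and a 1.7-fold lower number (0.22 log units; within the scatter) from compound 3 to compound 4, 1.3-fold (0.10 log units) apart, within the scatter of two such steps. Methyl on the acid oxygen, now read with 3-hydroxyphenyl in place, gives a 2.0-fold lower number from compound 2 to compound 4 (0.30 log units; within the scatter) and also agrees with its earlier reading: the same change on two cores in this assay, a 1.6-fold lower number (0.20 log units; within the scatter) from compound 1 to compound 3 and a 2.0-fold lower number (0.30 log units; within the scatter) from compound 2 to compound 4, 1.3-fold (0.10 log units) apart, within the scatter of two such steps. Among the compounds shown here, each change therefore reads alike whichever form the other place takes, though no single step exceeds the scatter.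

Still open, on these data alone, is whether an amine on the ring in place of the hydroxy, or a longer chain in place of the ester methyl, would shift the number beyond the scatter.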